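The compounds below may be only part of what the source reports. "The series", "measured", "known", "first", "only" and "open" are said of these compounds alone.

Measured in a physicochemical assay for lipophilicity, using the shake flask method; on this read-out higher numbers stand for higher lipophilicity and lower numbers for lower lipophilicity:
- Compound 1 `C[C@H](Oc1cc2cc(C(N)=O)ccc2nc1N)c1cc(F)c(F)cc1-n1cccn1` gives 3.2
- Compound 2 `C[C@H](Oc1cc2cc(C(N)=O)ccc2nc1N)c1cc2c(cnn2CCO)cc1-n1cccn1` gives 2.1
- Compound 3 `C[C@H](Oc1cc2c(F)ccc(F)c2nc1N)c1cc(C(=O)O)ccc1-n1cccn1` gives 1.1

Compound 2 stands second highest of the three. Compound 3 lies lower and compound 1 higher, and both gaps go beyond the scatter of repeated measurements.

Compound 4 `C[C@H](Oc1cc2cc(C(N)=O)ccc2nc1N)c1cc2[nH]ncc2cc1-n1cccn1` has not yet been measured. It differs from compound 2 in one place: hydrogen in place of 2-hydroxyethyl on an aromatic nitrogen.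

Going by the values given here, no two measured compounds differ in just one place, so the data offer no direct precedent for this change. The three measured compounds also differ from one another in more than one place, and their wide spread says little about this single substitution. The expectation therefore starts from the closest measured structure. Compound 4 shares everything except this one place with compound 2, which gives 2.1 as the starting point. A small upward step in this assay is expected, one that may not clear the scatter. The expected change is a number 0.30 log units higher from compound 2 to compound 4 (within the scatter) in this estimate. For compound 4 the estimated value is 2.4, with an expected range from 1.9 to 2.9.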

Compound 4, distribution coefficient: 2.7
Beside the measured number, compound 4's estimate is 0.30 log units below it; the range from low to high includes it.
By their numbers in this assay, from the lowest: compound 3; then compound 2; then compound 4; then compound 1.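

With hydrogen in place of 2-hydroxyethyl on an aromatic nitrogen of the five-membered aromatic ring, this assay shows a number 0.60 log units higher from compound 2 to compound 4 (beyond the scatter). Going by these compounds alone, this is the first pair here that differs in one place, so a change at this nitrogen can now be read on its own, in both direction and size, and it goes beyond the scatter, which the earlier compounds, differing from one another in more than one place, could not show. Nothing among the data shown accounts for the step, and the reason for it stays unexplained.

The compounds shown leave open where a methyl group, a longer chain, or a chain ending in an amine or a carboxylic acid would fall on this read-out if placed on the same nitrogen, and whether the step follows the hydroxyl of the 2-hydroxyethyl group or its carbon chain. This is also a single pair on a single core, and it leaves open whether the same exchange would give a step of similar size and the same direction in compounds that carry other groups elsewhere.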